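A Second Methyl on an Already Weak Acid

This account rests on a few compounds, and the source may have more. Where it says the series, first, only, none or still open, it means among the compounds named here.

The three measured compounds were tested in a functional assay on CHO cells for agonist activity at Free fatty acid receptor 1 (Homo sapiens), read by FLIPR and calcium flux; on this read-out higher numbers stand for an effect only at larger amounts of compound and lower numbers for an effect already at smaller amounts:

Compound 1 `CCOc1cc(C)c(-c2cccc(COc3ccc(S(=O)(=O)CC(=O)O)cc3)c2)c(C)c1`: 63.1 nM
Compound 2 `CCOc1ccc(-c2cccc(COc3ccc(S(=O)(=O)CC(=O)O)cc3)c2)c(Cl)c1`: 51.3 nM
Compound 3 `COc1cc(C)c(-c2cccc(COc3ccc(S(=O)(=O)C(C)C(=O)O)cc3)c2)c(C)c1`: > 1000 nM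

Compound 1 gives 63.1 nM and compound 2 gives 51.3 nM, and these two values lie within the usual scatter of each other. Compound 3 stands apart: its value of > 1000 nM is a limit of the assay and not a number, so compound 3 produced no effect up to the highest amount tested, as recorded in the limit of > 1000 nM in this assay, at which 1 of the 3 values shown sits.

Compound 4 `COc1cc(C)c(-c2cccc(COc3ccc(S(=O)(=O)C(C)(C)C(=O)O)cc3)c2)c(C)c1` differs from compound 3 in one place: methyl in place of hydrogen on a saturated chain carbon bound to a carbonyl carbon, a saturated chain carbon and a sulfonyl sulfur. In plain terms, a methyl takes the place of a hydrogen on a saturated chain carbon bound to a carbonyl carbon, a saturated chain carbon and a sulfonyl sulfur, so that the 1-carboxyethyl group becomes a 1-carboxy-1-methylethyl group.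

Going by the values given here, no pair of measured compounds differs in exactly one place, so no measured step tells how this change behaves. Compound 3 already sits at the limit, and the step that the limit leaves unreadable from compound 3 to compound 4 is expected to keep compound 4 at or beyond that limit, with no return toward the values of compound 1 and compound 2 expected. Compound 4 is therefore estimated at 3000 nM, within a range from 800 nM to 15000 nM.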

Compound 4, half-maximal effective concentration in the Free fatty acid receptor 1 assay: > 1000 nM
Compound 4: a limit, no number; the forecaster's own chance of this, stated with the estimate: 75%; the middle value does not contradict the limit.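

In the Free fatty acid receptor 1 assay, compound 3 gives > 1000 nM, which is a limit of the assay and not a number. In the Free fatty acid receptor 1 assay, compound 4 gives > 1000 nM, which is also a limit of the assay and not a number. Both compounds end at a limit, so no step between them can be read: the limit of > 1000 nM in the Free fatty acid receptor 1 assay, at which 2 of the 4 values shown sit.

In a physicochemical assay for lipophilicity, using the shake flask method, in phosphate buffer, measured as octanol-water partition, with a stated time of 24 h, at pH 7.4, tested at 100 uM (on this read-out lower numbers stand for lower lipophilicity and higher numbers for higher lipophilicity), compound 3 is recorded as "not determined" (no result reported) and compound 4 is recorded as "not determined" (no result reported), so no result is available to compare.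

The compounds shown leave open whether the 1-carboxy-1-methylethyl group of compound 4 gives any different response from the 1-carboxyethyl group of compound 3.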